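Lengthening the Sulfonyl Chain: Heptenyl to Decyl

The source may hold more compounds than are shown below. What is called first, only, known or untested is meant among the compounds shown, and "the series" means these compounds.

Within the data shown here, compound 1 `C=CCCCCCCS(=O)(=O)/C=C/c1ccc(O)c(O)c1` gives 6400 nM in a functional assay, read by fluorescence and spectrophotometry, with a stated time of 1 h (a lower number here means that less compound is needed, a higher number that more compound is needed for the effect), the lowest of the two numbers measured so far. Compound 2 `O=S(=O)(/C=C/c1ccc(O)c(O)c1)CC1CCCO1` gives 10500 nM in this assay, and the step of a 1.6-fold higher number from compound 1 to compound 2 (0.22 log units; within the scatter) stays within the scatter. Compound 3 `CCCCCCCCCCS(=O)(=O)/C=C/c1ccc(O)c(O)c1` differs from compound 1 by butyl in place of vinyl on a saturated chain carbon, six bonds along the chain from a sulfonyl sulfur. Among the measured compounds shown here, no measured step changes the chain at this place; the only guide is that swapping the whole chain barely moved the number. Compound 3 is therefore expected to give 5000 nM, with a range of 2500 nM to 12000 nM, an estimated step of a 1.3-fold lower number from compound 1 to compound 3 (0.11 log units; within the scatter), not beyond the scatter.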

Compound 3, half-maximal effective concentration: 6800 nM
Estimate against measurement, compound 3: 1.4-fold (0.13 log units) below; the measured number falls inside the stated range.
By their numbers in this assay, from the lowest: compounds 1, 3 and 2 (each within the scatter of the next).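

In this assay, butyl in place of vinyl on a saturated chain carbon, six bonds along the chain from a sulfonyl sulfur, gives a 1.1-fold higher number from compound 1 to compound 3 (0.03 log units; within the scatter). Between compound 1 and compound 3, then, the double bond of the vinyl group is not needed to keep the number, and the added length of the decyl chain leaves it within the scatter. Nothing measured here offers an explanation for this result.

As far as these compounds go, whether a still longer chain would also leave the number within the scatter remains open. So does the effect of an amine or a carboxylic acid at the end of the chain.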